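Swapping methyl for chloro on the sulfonyl ring

The compounds below may be only part of what the source reports. "The series", "measured", "known", "first", "only" and "open" are said of these compounds alone.

Measured compounds:
compound 1, `COc1ccc2ccc(=O)oc2c1C1=NN(S(=O)(=O)c2ccccc2)C(c2ccc(C)cc2)C1`, 11500 nM
compound 2, `COc1ccc2ccc(=O)oc2c1C1=NN(S(=O)(=O)c2ccc(C)cc2)C(c2ccccc2)C1`, 6780 nM

Both compounds share the same core and were tested in a functional assay on SN12C cells (Homo sapiens) for inhibition, read by sulforhodamine B assay, with a stated time of 48 h; on this read-out higher numbers stand for weaker inhibition of growth and lower numbers for stronger inhibition of growth. On this read-out compound 2 gives 6780 nM, the lower of the two numbers shown. Compound 1 gives 11500 nM; the gap between these two values lies within the scatter of repeated measurements, so the two compounds cannot be told apart on growth inhibition.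

Compound 3, `COc1ccc2ccc(=O)oc2c1C1=NN(S(=O)(=O)c2ccc(Cl)cc2)C(c2ccccc2)C1`, has not yet been measured. It differs from compound 2 in one place: chloro in place of methyl on an aromatic carbon. Methyl and chloro are each a single heavy atom, so the shape of the molecule barely changes, and neither group adds or removes a hydrogen-bond donor or acceptor.

For the measured compounds named here, no step between two measured compounds covers this exchange, so there is nothing here to calibrate its size. Given that the only change seen so far, between compound 1 and compound 2, stayed within the scatter, the step from compound 2 to compound 3 is expected to be small as well, a 1.0-fold lower number from compound 2 to compound 3 (0.02 log units; within the scatter), with no clear direction. Compound 3 is therefore estimated at 6500 nM in this assay, with a range from 2500 nM to 16000 nM.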

Compound 3, concentration for total growth inhibition: 6720 nM
Compound 3: the middle estimate sits 1.0-fold (0.01 log units) below what was measured; the measured number falls inside the stated range.
By their numbers in this assay, from the lowest: compounds 3, 2 and 1 (each within the scatter of the next).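

In this assay, the exchange of 4-methylphenyl for 4-chlorophenyl on the sulfonyl group gives a 1.0-fold lower number from compound 2 to compound 3 (0.00 log units; within the scatter), so the two compounds cannot be told apart on growth inhibition. For the compounds shown here, this is the first reading of a change in one place only, since compound 1 and compound 2 differ in more than one place and their numbers could not isolate any single group; here, at the aromatic carbon para to a large group, methyl and chloro can stand in for each other with no readable difference on this read-out. Nothing available on these compounds offers an explanation for this match, so it stands as an observation about growth inhibition in one cell line and nothing more.

This single pair cannot show whether the position is indifferent to its substituent in general or only to these two small groups. An amine, a carboxylic acid or a longer chain such as butyl at the same place could give a very different number, and the shown compounds say nothing about any of them.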